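Swapping the Ring on the Core Nitrogen: Compound 4

A few compounds are considered here, and "the series" means these few. Any claim that something is new, unique, unknown or untested is made for them only; others in the source may bear on it.

Measured so far:
compound 1 `COc1cc2c(Oc3ccc(NC(=O)c4nn(-c5ccccc5F)c(=O)c5ccccc45)cc3F)ccnc2cc1OCCCN1CCCC1` – 950 nM
compound 2 `COc1cc2c(Oc3ccc(NC(=O)c4nn(-c5ccccc5)c(=O)c5ccccc45)cc3F)ccnc2cc1OCCCN1CCN(C)CC1` – 1580 nM
compound 3 `COc1cc2c(Oc3ccc(NC(=O)c4nn(-c5ccccc5F)c(=O)c5ccccc45)cc3F)ccnc2cc1OCCCN1CCN(C)CC1` – 1050 nM

In a functional assay on MDA-MB-231 cells (Homo sapiens) for cytotoxicity, read by MTT assay, with a stated time of 72 h (a lower number here means a stronger inhibitor, a higher number a weaker inhibitor), compound 3 sits close to its two neighbours: the step of a 1.1-fold higher number from compound 1 to compound 3 (0.04 log units; within the scatter) and the step of a 1.5-fold lower number from compound 2 to compound 3 (0.18 log units; within the scatter) are both within the scatter, so none of the three can be called stronger or weaker than another.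

Compound 4 `COc1cc2c(Oc3ccc(NC(=O)c4nn(-c5ccc([N+](=O)[O-])cc5)c(=O)c5ccccc45)cc3F)ccnc2cc1OCCCN1CCN(C)CC1` differs from compound 3 by 4-nitrophenyl in place of 2-fluorophenyl on an aromatic nitrogen. For the measured compounds named here, the one measured step that touches this ring, a 1.5-fold lower number from compound 2 to compound 3 (0.18 log units; within the scatter), changed the number only within the scatter. Going by the values given here, the new ring carries a different group, and no measured pair shows what that brings, so a small step is expected. Compound 4 is therefore estimated to show a 1.2-fold higher number from compound 3 to compound 4 (0.09 log units; within the scatter), giving an expected 1300 nM, with a range from 450 nM to 3800 nM.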

Compound 4, half-maximal inhibitory concentration: 3490 nM
The estimate for compound 4 lay 2.7-fold (0.43 log units) below the measured number, and the stated range covers the measured number.
By their numbers in this assay, from the lowest: compounds 1, 3 and 2 (each within the scatter of the next); then compound 4.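

For the compounds shown here, with a 2.2-fold higher number from compound 2 to compound 4 (0.34 log units; beyond the scatter) and a 3.3-fold higher number from compound 3 to compound 4 (0.52 log units; beyond the scatter) on the ring on the aromatic nitrogen, this is the first change there that goes beyond the scatter. Fluoro in place of hydrogen had not done so, whereas the 4-nitrophenyl ring gives a weaker inhibitor, so this position does respond to what its ring carries. Nothing available explains why. Still open, as far as these compounds go, is whether an amine or a nitrile in place of nitro would give a similar number. From the compounds shown here alone, it is also open whether the 4-nitrophenyl ring would act alike with the pyrrolidin-1-yl chain.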